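This account rests on a few compounds, and the source may have more. Where it says the series, first, only, none or still open, it means among the compounds named here.

Measured so far in a functional assay on C8166 cells (Homo sapiens) for cytotoxicity, read by MTT assay; a higher number here means that more compound is tolerated, a lower number that less compound is tolerated:
compound 1 (`Cc1ccc(C(=O)Nc2cc(Cl)ccc2OCC(=O)Nc2ccc(S(N)(=O)=O)cc2C)cc1`) gives 54200 nM
compound 2 (`Cc1cc(S(N)(=O)=O)ccc1NC(=O)COc1ccc(Cl)cc1NC(=O)c1cccc(C(F)(F)F)c1`) gives 124000 nM
compound 3 (`Cc1cc(S(N)(=O)=O)ccc1NC(=O)COc1ccc(Cl)cc1NC(=O)c1ccc(Cl)cc1Cl`) gives 61100 nM

Compound 3 at 61100 nM sits level with compound 1 (a 1.1-fold higher number from compound 1 to compound 3 (0.05 log units; within the scatter)) and under compound 2 (a 2.0-fold lower number from compound 2 to compound 3 (0.31 log units; beyond the scatter)). Compound 4 (`Cc1cc(S(N)(=O)=O)ccc1NC(=O)COc1ccc(Cl)cc1NC(=O)/C=C/c1ccccc1`) keeps the shared core but carries 2-phenylethenyl in place of 2,4-dichlorophenyl on a carbonyl carbon. The remaining swap at this place gave a 2.3-fold higher number from compound 1 to compound 2 (0.36 log units; beyond the scatter) and is also modest. With all three steps this small, no step beyond the scatter is expected in this assay here. None of these swaps brought in 2-phenylethenyl, so the range stays wide. The estimated step is small (a 1.1-fold higher number from compound 3 to compound 4 (0.06 log units; within the scatter)). Compound 4 is estimated at 70000 nM with a range from 38000 nM to 130000 nM as the expected span.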

Compound 4, half-maximal cytotoxic concentration: 163000 nM
Beside the measured number, compound 4's estimate is 2.3-fold (0.37 log units) below it; the measured number lies above the stated range.
By their numbers in this assay, from the lowest: compounds 1 and 3 (each within the scatter of the next); then compounds 2 and 4 (each within the scatter of the next).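

In this assay, among these compounds, 2-phenylethenyl is the first group on this carbonyl carbon with a double bond outside the aromatic ring, and the number moves modestly upward (a 2.7-fold higher number from compound 3 to compound 4 (0.43 log units; beyond the scatter); a 3.0-fold higher number from compound 1 to compound 4 (0.48 log units; beyond the scatter)). The change also leaves it level with 3-(trifluoromethyl)phenyl (a 1.3-fold higher number from compound 2 to compound 4 (0.12 log units; within the scatter)), so two different groups now share the top of the series. Nothing available explains these steps.

Whether the double bond itself matters stays open, as 2-phenylethyl is not among these compounds. A group carrying an amine or a carboxylic acid at this place is also untested here.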